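Piperidin-1-yl for 4-methylpiperazin-1-yl on the shared core

The compounds below may be only part of what the source reports. "The series", "measured", "known", "first", "only" and "open" are said of these compounds alone.

Values in an ADME assay on L6 cells (Rattus norvegicus) for cytotoxicity, read by resazurin assay, with a stated time of 72 h (a lower number here means a stronger inhibitor, a higher number a weaker inhibitor), for the measured compounds:
- compound 1 `CN1CCN(CC(=O)OC2CC3(N(C)C)CC(c4ccccc4)C2C(c2ccccc2)C3)CC1` gives 39900 nM
- compound 2 `CN1CCN(CC(=O)NC2CC3(N4CCCC4)CC(c4ccccc4)C2C(c2ccccc2)C3)CC1` gives 50200 nM
- compound 3 `CN1CCN(CC(=O)OC2CC3(N4CCCC4)CC(c4ccccc4)C2C(c2ccccc2)C3)CC1` gives 24600 nM

Compound 3 stands level with compound 1 within the scatter, as the step of a 1.6-fold lower number from compound 1 to compound 3 (0.21 log units; within the scatter) shows, with pyrrolidin-1-yl in place of dimethylamino. It stands modestly under compound 2, by the step of a 2.0-fold lower number from compound 2 to compound 3 (0.31 log units; beyond the scatter) with the oxy linkage in place of the amino linkage.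

Compound 4 `O=C(CN1CCCCC1)OC1CC2(N3CCCC3)CC(c3ccccc3)C1C(c1ccccc1)C2` differs from compound 3 in one group: piperidin-1-yl in place of 4-methylpiperazin-1-yl on a saturated chain carbon bound to a carbonyl carbon. For the measured compounds named here, all three measured compounds carry 4-methylpiperazin-1-yl, so no measured step tests this exchange directly. The two steps above bear on it only as a guide to size, since they are changes elsewhere on the same scaffold and both are small. A step of similar small size is expected in this assay, leaning toward a lower number, though the data do not fix that direction. The estimate expects a 1.4-fold lower number from compound 3 to compound 4 (0.16 log units; within the scatter) as the step. For compound 4 the expected value is 17000 nM within an estimated range (from 6000 nM to 40000 nM).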

Compound 4, half-maximal inhibitory concentration: 14200 nM
Compound 4: the middle estimate sits 1.2-fold (0.08 log units) above what was measured; low and high end bracket the measured number.
By their numbers in this assay, from the lowest: compounds 4, 3, 1 and 2 (each within the scatter of the next, the first and the last beyond it).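

In this assay, the side group on a saturated chain carbon bound to a carbonyl carbon accepts piperidin-1-yl in place of 4-methylpiperazin-1-yl with only a 1.7-fold lower number from compound 3 to compound 4 (0.24 log units; within the scatter), so at this level of resolution the assay does not separate a ring with 2 hetero atoms from one with 1 hetero atom. Read as a single exchange of the whole group, (((piperidin-1-yl)methyl)carbonyl)oxy in place of (((4-methylpiperazin-1-yl)methyl)carbonyl)amino gives a 3.5-fold lower number from compound 2 to compound 4 (0.55 log units; beyond the scatter), a modest step but larger than any available among the earlier compounds. No measurement available here explains either step.

Still open, on these data alone, is whether other groups at this place, such as morpholin-4-yl, an open-chain diethylamino group or a cyclohexyl ring without nitrogen, would stay within the scatter of compound 3 or move the number further. Also open, as far as these compounds go, is whether piperidin-1-yl gives a similar result on the amide-linked form of the shared core or on the form carrying dimethylamino.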